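From Methoxy to Butoxy: A Cell Tolerance Question

The source may hold more compounds than are shown below. What is called first, only, known or untested is meant among the compounds shown, and "the series" means these compounds.

For the measured compounds named here, only two compounds have been measured so far in a functional assay on MDCK cells (Canis lupus familiaris) for inhibition (a lower number here means that less compound is tolerated, a higher number that more compound is tolerated), and they sit close together. Compound 1 (`CCCCOc1nc(CC2(C)CCCO2)cc(=O)n1C`) gives 1080000 nM as its reading, and compound 2 (`COc1nc(CC2CCCO2)cc(=O)n1C`) gives 1220000 nM as its reading, so compound 2 stands level with compound 1 within the usual scatter.

Compound 3 (`CCCCOc1nc(CC2CCCO2)cc(=O)n1C`) keeps the core of compound 2 and carries propyl in place of hydrogen on a saturated chain carbon bound to an oxygen on an aromatic ring. In simpler terms, methoxy becomes butoxy.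

Going by the values given here, no measured step isolates this change, so the evidence is thin. Compound 1 also carries butoxy, and its 1080000 nM lies within the scatter of the reading for compound 2, so no shift beyond the scatter is expected. The estimate is a 1.2-fold lower number from compound 2 to compound 3 (0.09 log units; within the scatter) and this expected step stays within the scatter, leaning slightly toward a lower number. For compound 3 the expected value is 1000000 nM in this assay with 500000 nM to 1700000 nM as the estimated range.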

Compound 3, half-maximal cytotoxic concentration: 579000 nM
For compound 3 the middle estimate is 1.7-fold (0.24 log units) above the measured one; the range from low to high includes it.
By their numbers in this assay, from the lowest: compounds 3, 1 and 2 (each within the scatter of the next, the first and the last beyond it).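

In this assay, the change from methoxy to butoxy now has a direct reading of its own, a 2.1-fold lower number from compound 2 to compound 3 (0.32 log units; beyond the scatter) and this shows that adding propyl at this position, on a saturated chain carbon bound to an oxygen on an aromatic ring, can lower the tolerated concentration, though the step lies only just beyond the scatter. The other new comparison holds butoxy fixed and changes one place elsewhere, with hydrogen in place of methyl on a saturated ring carbon, and it gives a 1.9-fold lower number from compound 1 to compound 3 (0.27 log units; within the scatter) so that this methyl cannot be said to matter on these readings. Nothing available explains why the longer chain goes with the lower number.

This conclusion about the chain rests on a single pair of compounds, so it remains unclear whether the number would fall steadily as the chain grows, or how an ethoxy or hexyloxy group would read at the same position. As far as these compounds go, the reading of a butoxy chain ending in an amine or a carboxylic acid also remains open, as does whether any such group would bring the tolerated concentration back up.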